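Cytotoxicity notes on a diaryl amino alcohol series

The source may hold more compounds than are shown below. What is called first, only, known or untested is meant among the compounds shown, and "the series" means these compounds.

Measured so far:
compound 1, `COc1nc(-c2ccccc2F)ccc1[C@@H](c1ccccc1)[C@@](O)(CCN(C)C)c1cccc2ccccc12`: "nd" (no result reported)
compound 2, `COc1ncc(-c2ccccc2)cc1[C@@H](c1ccccc1)[C@@](O)(CCN(C)C)c1ccccc1`: 11.9 ug/mL

In a toxicity assay on HeLa cells (Homo sapiens) for cytotoxicity (a lower number here means that less compound is tolerated, a higher number that more compound is tolerated), compound 1 stands without a single number; its entry is "nd" (no result reported). Compound 2 in this assay gives 11.9 ug/mL, the only numerical anchor in the series. Compound 3, `COc1nc(-c2ccc(C(F)(F)F)cc2)ccc1[C@@H](c1ccccc1)[C@@](O)(CCN(C)C)c1cccc2ccccc12`, is obtained from compound 1 through (4-(trifluoromethyl)phenyl in place of 2-fluorophenyl on an aromatic carbon), that is 4-(trifluoromethyl)phenyl in place of 2-fluorophenyl on an aromatic carbon. For the measured compounds named here, no step between two measured compounds in this assay is available, so the size of the change from compound 1 to compound 3 cannot be read from data; the working expectation is a small shift toward less compound being tolerated, quite possibly no further than the scatter. Compound 3 is therefore estimated at 8 ug/mL, with a range from 3 ug/mL to 25 ug/mL. This expectation rests loosely on compound 2, which gives 11.9 ug/mL in this assay.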

Compound 3, half-maximal cytotoxic concentration: > 64 ug/mL
Compound 3 ended at the assay's limit (the forecaster's own chance of this, stated with the estimate: 10%); middle value at least 8.0-fold (0.90 log units) away from the limit.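

In this assay compound 3 gives > 64 ug/mL, a limit of the assay and not a number. For the compounds shown here, compound 1 has no single number, so no step from compound 1 to compound 3 can be read. The compounds shown leave open how 4-(trifluoromethyl)phenyl in place of 2-fluorophenyl shifts cytotoxicity.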